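Expected Paw Edema Inhibition for a Methoxy Analog

A few compounds are considered here, and "the series" means these few. Any claim that something is new, unique, unknown or untested is made for them only; others in the source may bear on it.

Of the compounds shown here, three have been measured and a fourth awaits. Compound 1 `O=C(CO[N+](=O)[O-])Nc1ccc(C(=O)/C=C/c2ccc(Cl)cc2)cc1` gives 69% in a functional assay on the whole organism (strain albino) for inhibition, with Rattus norvegicus as the target, read by paw edema, with stated times of 30 min and 3 h, at a dose of 100 mg/kg by the oral route; on this read-out higher numbers stand for more inhibition at the one dose given (going by the name of the read-out) and lower numbers for less inhibition. Compound 2 `COc1ccc(/C=C/C(=O)c2ccc(NC(=O)CO[N+](=O)[O-])cc2)cc1` gives 53% in this assay, and compound 3 `CC(O[N+](=O)[O-])C(=O)Nc1ccc(C(=O)/C=C/c2ccc(Cl)cc2)cc1` gives 62% in this assay.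

The change from compound 1 to compound 2 is methoxy in place of chloro on an aromatic carbon, and the step it made is a number 16 percentage points lower from compound 1 to compound 2 (beyond the scatter). The change from compound 1 to compound 3 is methyl in place of hydrogen on a saturated chain carbon bound to a carbonyl carbon and an oxygen on an unsaturated carbon, with the step of a number 7 percentage points lower from compound 1 to compound 3 (within the scatter); this is also how the core of compound 3 and compound 4 differs from the core of compound 1 and compound 2.

Compound 4 `COc1ccc(/C=C/C(=O)c2ccc(NC(=O)C(C)O[N+](=O)[O-])cc2)cc1` has not yet been measured. Among the compounds with values here, it differs from compound 3 by methoxy in place of chloro on an aromatic carbon, which is the same change as the one from compound 1 to compound 2, made at the same place and on the same kind of ring. Among the compounds shown, this change has been seen only once with a measurement, so the expectation rests on that single pair. The step from compound 3 to compound 4 is expected to be about a number 16 percentage points lower from compound 3 to compound 4 (beyond the scatter) because the earlier step of a number 16 percentage points lower from compound 1 to compound 2 (beyond the scatter) lay beyond the scatter and there is nothing in the data to suggest a different outcome here. Compound 4 is therefore estimated to give about 46%, with a likely range from 34% to 58%.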

Compound 4, a percentage reported as inhibition, in the whole organism at one dose (the size of the read-out at that dose, not a potency): 50%
The estimate for compound 4 lay 4 percentage points below the measured number, and the stated range covers the measured number.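

Changing chloro to methoxy on the core that carries the extra methyl gives a number 12 percentage points lower from compound 3 to compound 4 (beyond the scatter) in this assay and this step matches the one seen on the other core: the same change on two cores in this assay, a number 16 percentage points lower (beyond the scatter) from compound 1 to compound 2 and a number 12 percentage points lower (beyond the scatter) from compound 3 to compound 4, 4 percentage points apart, within the scatter of two such steps. The methyl on the chain, now added to a methoxy compound, gives a number 3 percentage points lower from compound 2 to compound 4 (within the scatter) and it stays small on both cores: the same change on two cores in this assay, a number 7 percentage points lower (within the scatter) from compound 1 to compound 3 and a number 3 percentage points lower (within the scatter) from compound 2 to compound 4, 4 percentage points apart, within the scatter of two such steps. Across these four compounds, each change therefore gave much the same result whichever form the other part of the molecule took, so a step measured on one core served as a fair guide on the other, but this rests on just two cores and one pair of groups and does not show that the same would hold for other cores or other changes.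

The compounds shown leave open what other groups on the aromatic ring in place of chloro or methoxy, such as a fluoro, a nitrile or an amine, would do to the inhibition of paw swelling, and whether a longer chain in place of the methyl would stay as small a step. They also leave open how the reading would change if a hydroxyl or a carboxylic acid stood in place of the nitrate ester.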